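Bromo in Place of Fluoro: Compound 4 Awaits Measurement

The compounds below may be only part of what the source reports. "The series", "measured", "known", "first", "only" and "open" are said of these compounds alone.

In a functional assay on A549 cells (Homo sapiens) for inhibition, read by MTT assay, with a stated time of 72 h (a higher number here means a weaker inhibitor, a lower number a stronger inhibitor), compound 1 `Cc1ccc(-c2cc(C(=O)N3CCC4(CC3)CC(=O)c3nn(C(C)(C)C)cc3O4)c3ccccc3n2)cc1` gives 5300 nM, compound 2 `CC(C)(C)n1cc2c(n1)C(=O)CC1(CCN(C(=O)c3cc(-c4ccccc4Cl)nc4ccccc34)CC1)O2` gives 2180 nM and compound 3 `CC(C)(C)n1cc2c(n1)C(=O)CC1(CCN(C(=O)c3cc(-c4ccc(F)cc4)nc4ccccc34)CC1)O2` gives 5770 nM. Compound 3 therefore stands with compound 1, the two lying within the scatter of each other, while compound 2 is the strongest of the three. Compound 4 `CC(C)(C)n1cc2c(n1)C(=O)CC1(CCN(C(=O)c3cc(-c4ccc(Br)cc4)nc4ccccc34)CC1)O2` differs from compound 3 at a single site, with bromo in place of fluoro on an aromatic carbon, para to a large group (bromo in place of fluoro on an aromatic carbon). The closest measured change, between 4-methylphenyl and 4-fluorophenyl, is a 1.1-fold higher number from compound 1 to compound 3 (0.04 log units; within the scatter). Only the changes involving 2-chlorophenyl went beyond the scatter, and they were modest, at a 2.4-fold lower number from compound 1 to compound 2 (0.39 log units; beyond the scatter) and a 2.6-fold higher number from compound 2 to compound 3 (0.42 log units; beyond the scatter). Among the measured compounds shown here, no bromo compound has been measured, so the exchange in this assay is expected to produce no shift beyond the scatter. The expected step is a 1.3-fold lower number from compound 3 to compound 4 (0.11 log units; within the scatter). Compound 4 is estimated at 4500 nM, with an expected range of 2200 nM to 9000 nM.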

Compound 4, half-maximal inhibitory concentration: 9300 nM
Compound 4: the middle estimate sits 2.1-fold (0.32 log units) below what was measured; the measured number lies above the stated range.
By their numbers in this assay, from the lowest: compound 2; then compounds 1, 3 and 4 (each within the scatter of the next).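

In this assay, this position, para to a large group, now holds a third substituent with no shift beyond the scatter: bromo in place of fluoro gives a 1.6-fold higher number from compound 3 to compound 4 (0.21 log units; within the scatter), and bromo in place of methyl gives a 1.8-fold higher number from compound 1 to compound 4 (0.24 log units; within the scatter). The 4-bromophenyl group also separates from 2-chlorophenyl, with a 4.3-fold higher number from compound 2 to compound 4 (0.63 log units; beyond the scatter), so compound 2 alone stands apart from compounds 1, 3 and 4, which lie within the scatter of one another. Nothing available accounts for these numbers.

The compounds shown leave open whether the standing of compound 2 belongs to the chloro group itself or to its place on the phenyl ring, which a 4-chlorophenyl compound would help to separate. They also leave open how this position would respond to an amine or a carboxylic acid in place of bromo.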